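A Methyl on the Aromatic Ring of Compound 1

A few compounds are considered here, and "the series" means these few. Any claim that something is new, unique, unknown or untested is made for them only; others in the source may bear on it.

Compound 1 `CN1C(=O)C(O)(Cc2nnn[nH]2)c2ccccc21` is the anchor of this small set. Within the data shown here, in a functional assay on PC-3 cells (Homo sapiens) for antiproliferative activity, read by MTT assay, with a stated time of 48 h (on this read-out lower numbers stand for stronger inhibition and higher numbers for weaker inhibition), compound 1 gives 44800 nM, the only plain number among the three values shown. Compound 2 `CCN1C(=O)C(O)(Cc2nnn[nH]2)c2ccccc21` reaches only a limit of the assay, > 100000 nM. Compound 3 `O=C1N(Cc2ccc(Br)cc2)c2ccc(Br)cc2C1(O)Cc1nnn[nH]1` likewise sits at a limit, > 100000 nM. Among the measured compounds shown here, the one step between measured compounds that differ in a single place, an at least 2.2-fold higher number from compound 1 to compound 2 (0.34 log units; beyond the scatter), is a methyl in place of hydrogen on a saturated chain carbon bound to an amide-type nitrogen in a ring; its size is only a lower bound, set by the limit of > 100000 nM in this assay, at which 2 of the 3 values shown sit.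

Compound 4 `Cc1ccc2c(c1)C(O)(Cc1nnn[nH]1)C(=O)N2C` differs from compound 1 by methyl in place of hydrogen on an aromatic carbon, on an aromatic carbon of a six-membered aromatic ring of carbon only, meta to a fused ring and para to a fused ring. For the measured compounds named here, no measured step touches that ring; the only comparison at hand is the methyl growth at the ring nitrogen, an at least 2.2-fold higher number from compound 1 to compound 2 (0.34 log units; beyond the scatter), which weakened inhibition at least modestly. With nothing closer to lean on, compound 4 is expected to stay near compound 1, with a step of a 1.3-fold higher number from compound 1 to compound 4 (0.13 log units; within the scatter) and a real chance of landing at a limit. The estimate for compound 4 in this assay is 60000 nM, between 25000 nM and 150000 nM.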

Compound 4, half-maximal inhibitory concentration: > 100000 nM
Compound 4: no number, only a limit; the forecaster's own chance of this, stated with the estimate: 35%; middle value at least 1.6-fold (0.22 log units) away from the limit.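

Among these compounds, this position on the aromatic ring, which no earlier step touched, does not stay silent in this assay: methyl in place of hydrogen on this aromatic carbon gives an at least 2.2-fold higher number from compound 1 to compound 4 (0.34 log units; beyond the scatter). Alongside an at least 2.2-fold higher number from compound 1 to compound 2 (0.34 log units; beyond the scatter), this is a second place where a single added methyl takes the core of compound 1 out of the range of plain numbers. Compound 4 stands at a limit and not at a number, so this step is only a lower bound: the limit of > 100000 nM in this assay, at which 3 of the 4 values shown sit.

As far as these compounds go, whether a fluorine, a methoxy group or an amine on this same aromatic carbon would keep a plain number remains open. Also open, from the compounds shown here alone, is whether any change to compound 1 would lower its number rather than raise it.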